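This account rests on a few compounds, and the source may have more. Where it says the series, first, only, none or still open, it means among the compounds named here.

Measured so far:
- compound 1 `CCCCN(CCCC)Cc1cn(CC(O)COC(=O)NCc2ccccc2)nn1`: in an assay on nucleic acid for inhibition of Nucleic Acid, read by fluorescence, tested at 100 uM (on this read-out higher numbers stand for more inhibition at the one concentration tested (going by the name of the read-out) and lower numbers for less inhibition), compound 1 gives 42%
- compound 2 `CN(CCCc1ccccc1)Cc1cn(CC(O)COC(=O)NCc2ccccc2)nn1`: in the same assay compound 2 gives 79%

Of the compounds shown here, two have been measured, and they differ in more than one place, so no single change can be tied to the gap between them. What the two numbers do show is that compound 2 stands at the top of this small set, with compound 1 a long way beneath it, well beyond the usual scatter of the assay.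

The next compound keeps the whole of compound 2 except at one end. Compound 3 `CN(CCCc1ccccc1)Cc1cn(CC(O)COCc2ccccc2)nn1` carries the change (benzyl in place of benzylcarbamoyl on an oxygen on a saturated carbon), that is, benzyl in place of benzylcarbamoyl on an oxygen on a saturated carbon. The group that leaves brings a hydrogen-bond donor and a hydrogen-bond acceptor with it; the group that enters brings neither. How much this matters for inhibition in this assay is not known from the measured pair, since neither compound probes this spot.

The expectation is a fall from compound 2, of moderate size, written as a number 19 percentage points lower from compound 2 to compound 3 (beyond the scatter). Compound 3 is expected to give about 60%, with a plausible range from 35% to 80%.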

Compound 3, a percentage reported as inhibition, at one concentration (the size of the read-out at that concentration, not a potency): 18%
Compound 3: the middle estimate sits 42 percentage points above what was measured, outside the stated range (below it).
By their numbers in this assay, from the lowest: compound 3; then compound 1; then compound 2.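

Replacing benzylcarbamoyl with benzyl on an oxygen on a saturated carbon gives a number 61 percentage points lower from compound 2 to compound 3 (beyond the scatter) in this assay, the first sign that this end of the molecule matters for the read-out, since compound 1 and compound 2 differ elsewhere and share this group. A six-membered aromatic ring of carbon only is present on both sides of the change, so in this pair keeping that ring on the oxygen does not keep the high number; the change from compound 2 to compound 3 takes away the hydrogen-bond donor, the hydrogen-bond acceptor and the double bond outside the ring. Nothing measured explains why the number falls so far, and no outside data bear on it.

The donor, the acceptor and the extra heavy atoms all leave together, so the compounds shown cannot tell which of them counts. A benzoyl group on the same oxygen, which keeps a carbonyl but has no amide hydrogen, or a benzylcarbamoyl with a methyl on its nitrogen, would be needed to pull these apart.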